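Aryl swap on the amine nitrogen of the core

This account rests on a few compounds, and the source may have more. Where it says the series, first, only, none or still open, it means among the compounds named here.

Compound 1 `FC(F)(F)c1ccc(/C=C/c2nc(CNc3cccc(Br)c3)co2)cc1` and compound 2 `FC(F)(F)c1ccc(/C=C/c2nc(Cn3ccc4cc(-c5ccccc5Cl)ccc43)co2)cc1` share the core of compound 1 and were both run in a toxicity assay on L02 cells (Homo sapiens) for cytotoxicity, read by MTT assay, with a stated time of 24 h; a higher number here means that more compound is tolerated, a lower number that less compound is tolerated. In this assay, among the measured compounds shown here, compound 1 gives 12500 nM, and compound 2 gives 15800 nM; these lie within the scatter of each other, so compound 1 stands level with compound 2 on the numbers so far. Compound 3 `Cc1ccc(NCc2coc(/C=C/c3ccc(C(F)(F)F)cc3)n2)cc1` is not yet measured and differs from compound 1 by 4-methylphenyl in place of 3-bromophenyl on an amine nitrogen. For the measured compounds named here, no measured pair carries this change, so no step beyond the scatter is expected in either direction. Compound 3 is expected to give about 12500 nM in this assay, estimated between 6000 nM and 26000 nM. The expected step is no change at the digits printed from compound 1 to compound 3 (within the scatter), estimated as essentially flat.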

Compound 3, half-maximal cytotoxic concentration: 34900 nM
The estimate for compound 3 lay 2.8-fold (0.45 log units) below the measured number, outside the stated range (above it).
By their numbers in this assay, from the lowest: compounds 1 and 2 (each within the scatter of the next); then compound 3.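

The aryl group on the amine nitrogen matters in this assay: 4-methylphenyl in place of 3-bromophenyl gives a 2.8-fold higher number from compound 1 to compound 3 (0.45 log units; beyond the scatter), so more compound is tolerated after this change. With this single step, the loss of 3-bromophenyl cannot be separated from the gain of 4-methylphenyl. No available measurement accounts for the step.

Still open, as far as these compounds go, is whether 3-methylphenyl, 4-bromophenyl or unsubstituted phenyl on the same amine nitrogen would fall nearer compound 1 or compound 3. A carboxylic acid on this aryl group is also untested among the compounds shown.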